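Acyl urea series: halogen pattern change on the benzoyl group

The source may hold more compounds than are shown below. What is called first, only, known or untested is meant among the compounds shown, and "the series" means these compounds.

Measured compounds in a functional assay on MCF7 cells (Homo sapiens) for inhibition, read by MTT assay, with a stated time of 72 h; on this read-out higher numbers stand for weaker inhibition and lower numbers for stronger inhibition:
compound 1 `CN(C(=O)NC(=O)c1ccc(Cl)cc1Cl)c1nc(C(F)(F)F)c(C(=O)N/N=C/c2cccc(C(F)(F)F)c2)s1`: 10.7 ug/mL
compound 2 `CN(C(=O)NC(=O)c1ccc(Cl)cc1Cl)c1nc(C(F)(F)F)c(C(=O)N/N=C/c2ccc(C(F)(F)F)cc2)s1`: 8.42 ug/mL
compound 3 `CN(C(=O)NC(=O)c1ccc(Cl)cc1Cl)c1nc(C(F)(F)F)c(C(=O)N/N=C/c2ccccc2C(F)(F)F)s1`: 9.12 ug/mL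

All three measured compounds share one core and differ only in the placement of the trifluoromethyl group on the phenyl attached to the carbon with a double bond to nitrogen. The steps among them are small: a 1.3-fold lower number from compound 1 to compound 2 (0.10 log units; within the scatter), a 1.2-fold lower number from compound 1 to compound 3 (0.07 log units; within the scatter) and a 1.1-fold higher number from compound 2 to compound 3 (0.03 log units; within the scatter). Compound 3 therefore sits with its neighbours, and none of the three can be called more or less active than another on these numbers.

Compound 4 `CN(C(=O)NC(=O)c1c(F)cccc1F)c1nc(C(F)(F)F)c(C(=O)N/N=C/c2ccccc2C(F)(F)F)s1` keeps the arrangement of compound 3 on the hydrazone side and changes the other end: 2,6-difluorophenyl in place of 2,4-dichlorophenyl on a carbonyl carbon. For the measured compounds named here, no measured step touches this position; the three steps recorded all concern the trifluoromethylphenyl group and each lies within the scatter. Going by the values given here, there is thus no direct precedent for the size or direction of the change from compound 3 to compound 4, and the expectation rests on the observation that the series so far has been flat.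

The estimate for compound 4 is a number close to that of compound 3, with an expected step of a 1.1-fold higher number from compound 3 to compound 4 (0.04 log units; within the scatter), and a widened range to cover the untested change: 10 ug/mL, between 4.5 ug/mL and 25 ug/mL.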

Compound 4, half-maximal inhibitory concentration: 20.4 ug/mL
The estimate for compound 4 lay 2.0-fold (0.31 log units) below the measured number; low and high end bracket the measured number.
By their numbers in this assay, from the lowest: compounds 2, 3, 1 and 4 (each within the scatter of the next, the first and the last beyond it).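

In this assay, for the compounds shown here, the group on the carbonyl carbon is the first place where a change moves the number beyond the scatter: 2,6-difluorophenyl in place of 2,4-dichlorophenyl gives a 2.2-fold higher number from compound 3 to compound 4 (0.35 log units; beyond the scatter) and points toward weaker inhibition, though the step is modest. The three trifluoromethyl placements on the hydrazone side stayed within the scatter of one another, so the flatness seen there does not extend to this end of the molecule, and a swap that keeps the heavy-atom count, the carbon-only aromatic ring, the absence of donors and acceptors and the neutral charge can still register in this assay. No measurement shown bears on the cause of this step.

The change replaces chlorine with fluorine and alters the substitution pattern in a single move, so the compounds shown cannot separate the contribution of the halogen from that of its placement. Also open, on these data alone, are whether the step carries over to the hydrazone arrangements of compound 1 and compound 2, and how an unsubstituted phenyl or a cyclohexyl group on the same carbonyl carbon would read.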